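The source may report more compounds than this note shows. Statements on the series, on what has been measured and on what is new or still open speak of the compounds shown alone.

In a functional assay on HeLa cells (Homo sapiens) for antiproliferative activity, read by CCK-8 assay, with a stated time of 48 h (a lower number here means a stronger inhibitor, a higher number a weaker inhibitor), compound 3 `COc1ccc(/C=C\c2cc(OC)c(OC)c(OC)c2)cc1OCc1ccc(CNCCNC(C)=O)cc1` gives 6400 nM and compound 2 `COc1ccc(/C=C\c2cc(OC)c(OC)c(OC)c2)cc1OCc1ccc(CNCCN(C)C)cc1` gives 9400 nM, and a 1.5-fold lower number from compound 2 to compound 3 (0.17 log units; within the scatter) shows these two values level within the scatter. Compound 1 `COc1ccc(/C=C\c2cc(OC)c(OC)c(OC)c2)cc1OCc1ccc(CN2C[C@H](O)C[C@@H]2C(=O)O)cc1` gives > 10000 nM, which is a limit of the assay and not a number.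

Compound 4 `COc1ccc(/C=C\c2cc(OC)c(OC)c(OC)c2)cc1OCc1ccc(CN2CC[C@@H](C(=O)O)C2)cc1` carries 3-carboxypyrrolidin-1-yl in place of (2-acetamidoethyl)amino on a saturated chain carbon bound to an aromatic carbon. The group entering resembles the 2-carboxy-4-hydroxypyrrolidin-1-yl of compound 1, so the closest evidence is an at least 1.5-fold lower number from compound 1 to compound 3 (0.19 log units; that floor lies within the scatter), read in reverse, with an at least 1.0-fold lower number from compound 1 to compound 2 (0.02 log units; that floor lies within the scatter) alongside it. Both are floors within the scatter, so a modest move towards a higher number in this assay is expected. The estimated change is a 1.6-fold higher number from compound 3 to compound 4 (0.19 log units; within the scatter). Compound 4 is expected at 10000 nM, with an estimated range of 5000 nM to 20000 nM.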

Compound 4, half-maximal inhibitory concentration: 12800 nM
The estimate for compound 4 lay 1.3-fold (0.11 log units) below the measured number, within the range that was stated.
By their numbers in this assay, from the lowest: compounds 3, 2 and 4 (each within the scatter of the next).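

In this assay, putting 3-carboxypyrrolidin-1-yl on this saturated chain carbon bound to an aromatic carbon gives a 2.0-fold higher number from compound 3 to compound 4 (0.30 log units; within the scatter) and a 1.4-fold higher number from compound 2 to compound 4 (0.13 log units; within the scatter). A ring bearing a carboxylic acid therefore now has a readable number, and it stays level within the scatter with both open-chain amines. Compound 1 carries a limit and not a number, so its step to compound 4 cannot be read: the limit of > 10000 nM in this assay, at which 1 of the 4 values shown sits.

Left open is whether a morpholine ring, or a longer chain ending in a carboxylic acid, at this place would move the number beyond the scatter.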